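Adding a second methoxy group to the pyrazole-side aryl ring

A few compounds are considered here, and "the series" means these few. Any claim that something is new, unique, unknown or untested is made for them only; others in the source may bear on it.

The measured compounds:
compound 1 `COc1ccc(-c2cc(/C=C/C(=O)c3ccc(N)cc3)[nH]n2)cc1` gives 1000 nM in a functional assay on HCT-15 cells (Homo sapiens) for inhibition, read by sulforhodamine B assay, with a stated time of 48 h; a lower number here means a stronger inhibitor of growth, a higher number a weaker inhibitor of growth
compound 2 `COc1ccc(C(=O)/C=C/c2cc(-c3cc(OC)c(OC)c(OC)c3)n[nH]2)cc1OC` gives 1270 nM in this assay
compound 3 `COc1cc(-c2cc(/C=C/C(=O)c3ccc(F)c(F)c3)[nH]n2)cc(OC)c1OC` gives 3010 nM in this assay

Compound 1 gives the lowest of the three numbers in this assay; compound 2 sits close to it, within the usual scatter, and compound 3 lies furthest away, beyond the scatter. Within the data shown here, the one step measured within this set, a 2.4-fold higher number from compound 2 to compound 3 (0.37 log units; beyond the scatter), concerns the aryl ring on the carbonyl carbon and is modest in size.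

Compound 4 `COc1ccc(-c2cc(/C=C/C(=O)c3ccc(N)cc3)[nH]n2)cc1OC` differs from compound 1 by methoxy in place of hydrogen on an aromatic carbon of the ring attached to the shared core, on the side away from the carbonyl. Among the measured compounds shown here, no measured step touches this ring, so the change is not directly covered. Compound 2, which carries three methoxy groups on that same ring, gives 1270 nM, within the scatter of compound 1. A step from compound 1 to compound 4 of no more than the scatter is therefore expected, in no settled direction.

For compound 4 the estimate in this assay is 1100 nM, with a range from 500 nM to 2500 nM. The expected step for compound 4 is a 1.1-fold higher number from compound 1 to compound 4 (0.04 log units; within the scatter).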

Compound 4, concentration for 50% growth inhibition: 1700 nM
The estimate for compound 4 lay 1.5-fold (0.19 log units) below the measured number; low and high end bracket the measured number.
By their numbers in this assay, from the lowest: compounds 1, 2, 4 and 3 (each within the scatter of the next, the first and the last beyond it).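

Methoxy in place of hydrogen on an aromatic carbon, ortho to a methoxy group and meta to a large group, gives a 1.7-fold higher number from compound 1 to compound 4 (0.23 log units; within the scatter) in this assay. Among these compounds, this is the first direct measurement on this ring, where the earlier compounds offered no single-place step, and it shows that this carbon takes the methoxy group without a difference that can be told from the usual scatter of the read-out. Nothing available explains this result, and no measured property of the compounds bears on it.

The compounds shown leave open whether a hydroxy group, a chlorine atom or an ethoxy chain on this same carbon would also stay within the scatter. They also leave open whether the methoxy step would stay this small with a different aryl ring on the carbonyl carbon.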